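This account rests on a few compounds, and the source may have more. Where it says the series, first, only, none or still open, it means among the compounds named here.

Three compounds share one core and differ only in the substituted phenyl group on the chain. In a functional assay on MCF7 cells (Homo sapiens) for cytotoxicity (on this read-out lower numbers stand for stronger inhibition and higher numbers for weaker inhibition), compound 3 (`C=C/C=C\[C@H](C)[C@H](OC(N)=O)[C@@H](C)[C@H](O)[C@@H](C)C/C(C)=C\[C@H](C)[C@@H](O)[C@@H](C)/C=C\CCc1cccc(Cl)c1`) gives 400 nM and compound 2 (`C=C/C=C\[C@H](C)[C@H](OC(N)=O)[C@@H](C)[C@H](O)[C@@H](C)C/C(C)=C\[C@H](C)[C@@H](O)[C@@H](C)/C=C\CCc1cccc(O)c1C`) gives 490 nM. These two cannot be told apart, as a 1.2-fold lower number from compound 2 to compound 3 (0.09 log units; within the scatter) lies within the scatter. Compound 1 (`C=C/C=C\[C@H](C)[C@H](OC(N)=O)[C@@H](C)[C@H](O)[C@@H](C)C/C(C)=C\[C@H](C)[C@@H](O)[C@@H](C)/C=C\CCc1ccc(C)c(F)c1`) gives 1000 nM, the highest number of the three.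

Compound 4 (`C=C/C=C\[C@H](C)[C@H](OC(N)=O)[C@@H](C)[C@H](O)[C@@H](C)C/C(C)=C\[C@H](C)[C@@H](O)[C@@H](C)/C=C\CCc1cc(F)cc(F)c1`) has not yet been measured. It carries 3,5-difluorophenyl in place of the 3-chlorophenyl of compound 3, on a saturated chain carbon, two bonds along the chain from a double-bonded chain carbon: 3,5-difluorophenyl in place of 3-chlorophenyl on a saturated chain carbon, two bonds along the chain from a double-bonded chain carbon. Going by the values given here, no measured step makes exactly this exchange, but all three change the phenyl group at this same place. The two that exceed the scatter are modest: a 2.0-fold lower number from compound 1 to compound 2 (0.31 log units; beyond the scatter) and a 2.5-fold lower number from compound 1 to compound 3 (0.40 log units; beyond the scatter). A small step in this assay is therefore expected, with no firm direction and probably nothing beyond the scatter. The expected change is a 1.3-fold higher number from compound 3 to compound 4 (0.10 log units; within the scatter). The estimate for compound 4 is 500 nM, with an expected range from 200 nM to 1200 nM.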

Compound 4, half-maximal inhibitory concentration: 600 nM
Beside the measured number, compound 4's estimate is 1.2-fold (0.08 log units) below it, and the stated range covers the measured number.
By their numbers in this assay, from the lowest: compounds 3, 2, 4 and 1 (each within the scatter of the next, the first and the last beyond it).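

In this assay, the 3,5-difluorophenyl group cannot be told apart from any of the three earlier phenyl groups: a 1.5-fold higher number from compound 3 to compound 4 (0.18 log units; within the scatter), a 1.2-fold higher number from compound 2 to compound 4 (0.09 log units; within the scatter) and a 1.7-fold lower number from compound 1 to compound 4 (0.22 log units; within the scatter) all lie within the scatter. Compound 4 thus sits within the scatter of both compound 1 and compound 3, although those two are separated by more than the scatter, so the small differences at this position now form a continuous run, and swapping one chlorine for two fluorines on the ring produces no readable change. No data here offer a reason for these numbers.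

All the rings shown carry halogen, methyl or hydroxy groups. On these data alone, how an amine or a carboxylic acid on the ring would behave stays open, as does a longer chain leading to the ring.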